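Acyl variation on the proline cap of the sulfonamide series

The source may hold more compounds than are shown below. What is called first, only, known or untested is meant among the compounds shown, and "the series" means these compounds.

Measured so far:
compound 1, `O=C(Cn1ccnc1)N1CCC(NS(=O)(=O)c2cc(S(=O)(=O)c3ccccc3)ccc2C(F)(F)F)CC1`: 30 nM
compound 2, `O=C1CC[C@@H](C(=O)N2CCC(NS(=O)(=O)c3cc(S(=O)(=O)c4ccccc4)ccc3C(F)(F)F)CC2)N1`: 90 nM
compound 3, `CC(C)(C)C(=O)N1CCC[C@H]1C(=O)N1CCC(NS(=O)(=O)c2cc(S(=O)(=O)c3ccccc3)ccc2C(F)(F)F)CC1`: 40 nM

In an assay on isolated protein for binding affinity to secreted frizzled-related protein 1 (Homo sapiens), read by fluorescence (on this read-out lower numbers stand for stronger inhibition and higher numbers for weaker inhibition), compound 3 holds the second highest of the three numbers; compound 1 sits nearest, a 1.3-fold higher number from compound 1 to compound 3 (0.12 log units; within the scatter), and compound 2 furthest, a 2.3-fold lower number from compound 2 to compound 3 (0.35 log units; beyond the scatter). Compound 4, `O=C([C@@H]1CCCN1C(=O)N1CCOCC1)N1CCC(NS(=O)(=O)c2cc(S(=O)(=O)c3ccccc3)ccc2C(F)(F)F)CC1`, is not yet measured. It differs from compound 3 in one place: morpholin-4-yl in place of tert-butyl on a carbonyl carbon. For the measured compounds named here, no measured step alters the tert-butyl itself; the exchanges of the whole group on the carbonyl carbon, a 3.0-fold higher number from compound 1 to compound 2 (0.48 log units; beyond the scatter) and a 2.3-fold lower number from compound 2 to compound 3 (0.35 log units; beyond the scatter), both stay modest, so this region tolerates variation. For compound 4 the expected change in this assay is small, direction uncertain, a 1.3-fold higher number from compound 3 to compound 4 (0.10 log units; within the scatter). Compound 4 is estimated at 50 nM, range 20 nM to 120 nM.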

Compound 4, half-maximal inhibitory concentration: 40 nM
Compound 4: the middle estimate sits 1.3-fold (0.10 log units) above what was measured; the range from low to high includes it.
By their numbers in this assay, from the lowest: compounds 1, 3 and 4 (each within the scatter of the next); then compound 2.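

In this assay, morpholin-4-yl in place of tert-butyl on the carbonyl carbon gives no change at the digits printed from compound 3 to compound 4 (within the scatter). The earlier steps shown here exchanged the whole group on the other carbonyl carbon, whereas this one alters the end of the acyl cap itself. A six-membered non-aromatic ring and a hydrogen-bond acceptor enter there with no shift beyond the scatter, although no available evidence bears on why the two groups read alike.

Going by these compounds, it remains open whether a piperazine, a carboxylic acid or a longer chain on this carbonyl carbon would also leave the number in place.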